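This account rests on a few compounds, and the source may have more. Where it says the series, first, only, none or still open, it means among the compounds named here.

Measured so far in an ADME assay on cells (Hepatocyte, Rattus norvegicus) for metabolic stability; on this read-out higher numbers stand for fast clearance and lower numbers for slow clearance:
compound 1, `CC(C)n1cc(-c2ccnc3[nH]c(C4CCNCC4)cc23)ccc1=O` — < 1 uL/min
compound 2, `CC(=O)N1CCC(c2cc3c(-c4ccc(=O)n(C(C)C)c4)ccnc3[nH]2)CC1` — 2.8 uL/min
compound 3, `COc1cc(F)ccc1-c1ccnc2[nH]c(C3CCN(CC(=O)N(C)C)CC3)cc12` — 38 uL/min

The value of compound 1 is a limit of the assay and not a number (the limit of < 1 uL/min in this assay, at which 1 of the 3 values shown sits). Of the two numbers in hand, compound 2 gives the lower one, and compound 3 gives a number well above it. Among the measured compounds shown here, the only step between single-point neighbours is an at least 2.8-fold higher number from compound 1 to compound 2 (0.44 log units; beyond the scatter), which, with compound 1 sitting at the limit, is a bound rather than a full measurement.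

Compound 4, `CC(C)n1cc(-c2ccnc3[nH]c(C4CCN(CC(=O)N5CCCCC5)CC4)cc23)ccc1=O`, differs from compound 2 by ((piperidin-1-yl)carbonyl)methyl in place of acetyl on an amine nitrogen in a ring. For the measured compounds named here, the same ring nitrogen is the site of the one measured step, and compound 3 carries a related carbonylmethyl group on that nitrogen while giving 38 uL/min. A further step upward in this assay, beyond the scatter, is therefore expected, with the expected size being a 5.4-fold higher number from compound 2 to compound 4 (0.73 log units; beyond the scatter). Compound 4 is thus estimated at 15 uL/min, within a range of 5 uL/min to 45 uL/min.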

Compound 4, intrinsic clearance in a liver preparation (reported as CLH), per the amount of preparation that the assay uses: 26 uL/min
For compound 4 the middle estimate is 1.7-fold (0.24 log units) below the measured one; low and high end bracket the measured number.
By their numbers in this assay, from the lowest: compound 2; then compounds 4 and 3 (each within the scatter of the next). At a limit, below all of these: compound 1.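

In this assay, ((piperidin-1-yl)carbonyl)methyl in place of acetyl on the amine nitrogen in a ring gives a 9.3-fold higher number from compound 2 to compound 4 (0.97 log units; beyond the scatter), so the read-out at this position depends on which group the nitrogen carries, not only on whether the nitrogen is substituted. Set against the unsubstituted amine of the core, the same group gives an at least 26-fold higher number from compound 1 to compound 4 (1.41 log units; beyond the scatter), and this step is a bound rather than a full measurement. The value of compound 1 is a limit and not a number: the limit of < 1 uL/min in this assay, at which 1 of the 4 values shown sits.

Still open, on these data alone, is whether the rise follows the piperidin-1-yl part of the new group or its carbonylmethyl part. A morpholine amide or a simple ethyl group on the same nitrogen would bear on that question.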